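The source may report more compounds than this note shows. Statements on the series, on what has been measured and on what is new or still open speak of the compounds shown alone.

Among the compounds with values here, compound 1 `CCCc1csc(CN[C@@H]2C[C@H]3C[C@@H]([C@H]2C)C3(C)C)c1` is the only compound in this set for which an ADME assay on MDCK cells (Canis lupus familiaris) for cytotoxicity, read by microscopy, with a stated time of 48 h (on this read-out lower numbers stand for higher toxicity in this test and higher numbers for lower toxicity in this test), returned an actual number: in this assay compound 1 gives 12500 nM. Compound 2 `C[C@H]1[C@H](NCc2ccoc2)C[C@H]2C[C@@H]1C2(C)C` is known only as a limit of the assay, with compound 2 giving > 100000 nM in this assay. Compound 3 `C[C@H]1[C@H](NCc2cncs2)C[C@H]2C[C@@H]1C2(C)C` likewise stands at a limit, compound 3 giving > 100000 nM in this assay. Within the data shown here, the one step between measured compounds, a step that the two limits leave unreadable from compound 2 to compound 3, therefore cannot be sized, and two of the three values sit at the limit of > 100000 nM in this assay, at which 2 of the 3 values shown sit.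

Compound 4 `C[C@H]1[C@H](NCc2cc(-c3ccsc3)cs2)C[C@H]2C[C@@H]1C2(C)C` differs from compound 1 in a single place: thiophen-3-yl in place of propyl on an aromatic carbon. Among the measured compounds shown here, no measured step bears on this change. The only step shown, a step that the two limits leave unreadable from compound 2 to compound 3, swaps one five-membered ring for another at a different place in the molecule and is unreadable, so it gives no guide to direction or size. What remains is the number for compound 1 and the two limits, which leave the expected step in this assay open in either direction.

With compound 1 as the sole anchor, compound 4 is expected to give about 10000 nM in this assay, with a wide range from 2500 nM to 50000 nM. This estimate means an expected step of a 1.3-fold lower number from compound 1 to compound 4 (0.10 log units; within the scatter), one that is not expected to go beyond the scatter.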

Compound 4, minimum cytotoxic concentration: 25000 nM
Estimate against measurement, compound 4: 2.5-fold (0.40 log units) below, and the stated range covers the measured number.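

In this assay, putting a thiophen-3-yl ring where the propyl chain stood gives a 2.0-fold higher number from compound 1 to compound 4 (0.30 log units; within the scatter), so the two compounds cannot be told apart on this read-out. Within the data shown here, this is the first direct look at this place, an aromatic carbon two ring bonds from the ring sulfur, and it shows that an open chain of 3 carbon atoms and a five-membered aromatic ring holding a sulfur can each stand there without a step beyond the usual scatter of the test. Nothing among the compounds shown explains why the two read alike.

As far as these compounds go, whether a carboxylic acid, an amine or a longer chain on this same aromatic carbon would also stay within the scatter of these two compounds remains open, since the propyl and thiophen-3-yl groups carry no charge and both lack a hydrogen-bond donor. A single pair also cannot say whether the same swap would read alike on a different core, or whether a group at this place would matter more or less than the ring that bears the amine.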